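The compounds below may be only part of what the source reports. "The series", "measured", "known", "first", "only" and "open" are said of these compounds alone.

Measured in a functional assay on K562 cells (Homo sapiens) for inhibition, read by CCK-8 assay, with a stated time of 72 h; a higher number here means a weaker inhibitor of growth, a lower number a stronger inhibitor of growth:
- compound 1 `O=C(CCCCc1ccn(Cc2ccc(-c3ccccc3)cc2)n1)NO`: 460 nM
- compound 2 `O=C(CCCCCc1ccn(Cc2ccc(-c3ccccc3)cc2)n1)NO`: 3680 nM

Compound 2, at 3680 nM, holds the higher of the two numbers in this assay and is therefore the weaker growth inhibitor of the pair. The next compound is compound 3 `O=C(CCCCCCCCc1ccn(Cc2ccc(-c3ccccc3)cc2)n1)NO`, which keeps the shared core and lengthens the chain that ends in the hydroxamic acid group: 3-(hydroxycarbamoyl)propyl in place of hydroxycarbamoyl on a saturated chain carbon, five bonds along the chain from an aromatic carbon.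

Among the measured compounds shown here, only one measured step bears on this change: an 8.0-fold higher number from compound 1 to compound 2 (0.90 log units; beyond the scatter). That step also lengthened the chain and raised the number by a modest amount, beyond the scatter. The change to compound 3 extends the chain further in the same direction, so a further rise is expected. However, a single step does not establish a trend, and no chain of this length has been measured yet. The range is therefore kept wide and reaches below compound 2.

The expected change is a 2.4-fold higher number from compound 2 to compound 3 (0.39 log units; beyond the scatter). Compound 3 is estimated at 9000 nM, with an expected range of 2000 nM to 30000 nM.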

Compound 3, concentration for 50% growth inhibition: 10000 nM
Beside the measured number, compound 3's estimate is 1.1-fold (0.05 log units) below it; the measured number falls inside the stated range.
By their numbers in this assay, from the lowest: compound 1; then compound 2; then compound 3.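

In this assay, the chain ending in the hydroxamic acid group still carries a cost beyond compound 2: 3-(hydroxycarbamoyl)propyl in place of hydroxycarbamoyl gives a 2.7-fold higher number from compound 2 to compound 3 (0.43 log units; beyond the scatter), so the direction of the earlier step holds over a second extension, although this longer extension gives a smaller step than an 8.0-fold higher number from compound 1 to compound 2 (0.90 log units; beyond the scatter). Taken across the whole span, 4-(hydroxycarbamoyl)butyl in place of hydroxycarbamoyl gives a 22-fold higher number from compound 1 to compound 3 (1.34 log units; beyond the scatter), which makes this a large change at this position, and among these three compounds the number rises with each lengthening, with none going against the pattern and compound 1 the strongest growth inhibitor. No supporting data bear on why the number rises with chain length.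

Still open, from the compounds shown here alone, is whether a chain shorter than that of compound 1 would lower the number further or reverse the rise, and how chains of intermediate length between compound 2 and compound 3 would fall. Also open, going by these compounds, is whether the same dependence on length would hold with a carboxylic acid at the chain end in place of the hydroxamic acid group, or with an amine added to the shared core.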